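Chain lengthening from compound 3 to compound 4

A few compounds are considered here, and "the series" means these few. Any claim that something is new, unique, unknown or untested is made for them only; others in the source may bear on it.

Compound 3 `CCCCCCCCCCOc1ccc(NC(=O)O/N=C/c2ccccc2)cc1` stands lowest of the three measured numbers in an assay on H4 cells for inhibition of Fatty-acid amide hydrolase 1 (Homo sapiens); on this read-out higher numbers stand for weaker inhibition and lower numbers for stronger inhibition: compound 3 gives 0.35 nM. Compound 2 `CCCCCCCCCCCCOc1ccc(NC(=O)ON=C(C)C)cc1` comes nearest; in this assay compound 2 gives 5 nM. Compound 1 `CCCCCCCCCCCCOc1ccc(NC(=O)Oc2ccccc2F)cc1` lies furthest off, as in this assay compound 1 gives 13 nM. For the measured compounds named here, the only step between measured compounds that differ in a single place is a 2.6-fold lower number from compound 1 to compound 2 (0.41 log units; beyond the scatter), and it changes the group on an oxygen next to a carbonyl group, not the chain.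

Compound 4 `CCCCCCCCCCCCOc1ccc(NC(=O)O/N=C/c2ccccc2)cc1` differs from compound 3 by ethyl in place of hydrogen on a saturated chain carbon, ten or more bonds along the chain from an oxygen on an aromatic ring. Going by the values given here, no measured step touches the chain, so nothing among the measured numbers bears directly on this change; the step from compound 1 to compound 2 concerns a different part of the molecule. With no evidence either way, the step expected here is a 1.1-fold higher number from compound 3 to compound 4 (0.06 log units; within the scatter), that is, none beyond the scatter. Compound 4 is accordingly expected to give 0.4 nM in this assay, with a range from 0.1 nM to 1.6 nM.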

Compound 4, half-maximal inhibitory concentration: 2.4 nM
For compound 4 the middle estimate is 6.0-fold (0.78 log units) below the measured one; the measured number lies above the stated range.
By their numbers in this assay, from the lowest: compound 3; then compound 4; then compound 2; then compound 1.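

In this assay, for the compounds shown here, the chain is not a silent part of the molecule: ethyl in place of hydrogen on a saturated chain carbon, ten or more bonds along the chain from an oxygen on an aromatic ring, gives a 6.9-fold higher number from compound 3 to compound 4 (0.84 log units; beyond the scatter) as the first measured step at this position. With the chain held the same, the group that the chain step left unchanged on the oxygen next to a carbonyl group also separates from the two other groups there, with a 2.1-fold lower number from compound 2 to compound 4 (0.32 log units; beyond the scatter) and a 5.4-fold lower number from compound 1 to compound 4 (0.73 log units; beyond the scatter) as its steps. Nothing available explains the size of the chain step.

This single pair gives one chain change with one group on that oxygen, so it sets no trend along the chain. As far as these compounds go, whether a longer chain, or a chain carrying a carboxylic acid, would move the number further in this assay stays open.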